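Replacing a Phenyl with Isobutyl: Expected Solubility

The compounds below may be only part of what the source reports. "The series", "measured", "known", "first", "only" and "open" are said of these compounds alone.

Compound 1, `COc1cccc(CNCCCNc2ccnc3cc(Oc4ccc(Cl)cc4)ccc23)c1O`: 14500 nM
Compound 2, `COc1cccc(CNCCCNc2ccnc3cc(Oc4ccc(F)cc4)ccc23)c1O`: 14500 nM
Compound 3, `COc1cccc(CNCCCNc2ccnc3cc(-c4ccccc4)ccc23)c1O`: 32000 nM

The read-out is a physicochemical assay for solubility, with a stated time of 18 h, at pH 7.4 (on this read-out lower numbers stand for lower solubility and higher numbers for higher solubility), measured for three compounds that share one core and differ only in the group on one aromatic carbon. Compound 3 holds the highest of the three numbers. Both steps that lead to it are beyond the scatter: a 2.2-fold higher number from compound 1 to compound 3 (0.34 log units; beyond the scatter) and a 2.2-fold higher number from compound 2 to compound 3 (0.34 log units; beyond the scatter). By contrast, no change at the digits printed from compound 1 to compound 2 (within the scatter), so compound 1 and compound 2 cannot be ordered against each other.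

Compound 4, `COc1cccc(CNCCCNc2ccnc3cc(CC(C)C)ccc23)c1O`, has not been measured yet. It differs from compound 3 in a single place: isobutyl in place of phenyl on an aromatic carbon. Among the measured compounds shown here, the only measured steps that bear on this are the two ending at compound 3, each a modest rise when phenyl took the place of 4-chlorophenoxy or 4-fluorophenoxy. For the measured compounds named here, no measured step involves an isobutyl group, and no step swaps a ring for a chain, so there is no direct guide to the direction. The expected step of a 1.1-fold higher number from compound 3 to compound 4 (0.04 log units; within the scatter) is therefore small and may well stay within the scatter. Compound 4 is estimated to give 35000 nM, with a range from 15000 nM to 80000 nM.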

Compound 4, solubility: 4200 nM
Compound 4: the middle estimate sits 8.3-fold (0.92 log units) above what was measured; measured number below the stated range.
By their numbers in this assay, from the lowest: compound 4; then compounds 1 and 2 (each within the scatter of the next); then compound 3.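

In this assay, this position proves sensitive to losing the aromatic ring from its substituent: there is a 7.6-fold lower number from compound 3 to compound 4 (0.88 log units; beyond the scatter) when isobutyl replaces phenyl. The isobutyl compound also stands apart from the two compounds with a substituted phenoxy group, with a 3.5-fold lower number from compound 2 to compound 4 (0.54 log units; beyond the scatter) for isobutyl in place of 4-fluorophenoxy and a 3.5-fold lower number from compound 1 to compound 4 (0.54 log units; beyond the scatter) for isobutyl in place of 4-chlorophenoxy, so all three groups with an aromatic ring give higher numbers than the open chain among these four compounds. Group size alone does not order the results, since going from 4-chlorophenoxy or 4-fluorophenoxy to the smaller phenyl raised the number, while going from phenyl to the smaller isobutyl lowered it.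

No measurement shown here accounts for the fall seen with isobutyl. The compounds also leave open whether this result belongs to isobutyl alone or to non-aromatic groups more widely, a question that a cyclohexyl group, a longer chain or an amine on the same carbon could help to answer.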